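Dihalophenyl versus methoxyphenyl on the enone carbonyl

The source may hold more compounds than are shown below. What is called first, only, known or untested is meant among the compounds shown, and "the series" means these compounds.

Compound 3 `COc1ccc(C(=O)/C=C/c2cc(-c3cc(OC)c(OC)c(OC)c3)n[nH]2)cc1` gives the lowest number of the three measured in a functional assay on RXF 393 cells (Homo sapiens) for cytotoxicity, read by sulforhodamine B assay, with a stated time of 48 h, tested at 10 uM (on this read-out lower numbers stand for a stronger effect and higher numbers for a weaker effect at the one concentration tested), at -97%. Compound 2 `COc1ccc(-c2cc(/C=C/C(=O)c3cc(OC)c(OC)c(OC)c3)[nH]n2)cc1OC` comes nearest with -80%, and compound 1 `COc1cc(-c2cc(/C=C/C(=O)c3ccc(Cl)c(Cl)c3)[nH]n2)cc(OC)c1OC` is furthest at 9%. Compound 4 `COc1cc(-c2cc(/C=C/C(=O)c3ccc(F)c(F)c3)[nH]n2)cc(OC)c1OC` differs from compound 3 by 3,4-difluorophenyl in place of 4-methoxyphenyl on a carbonyl carbon. Among the measured compounds shown here, the one measured step that bears on this is the reverse exchange at the same carbonyl carbon, where the number moved a number 106 percentage points lower from compound 1 to compound 3 (beyond the scatter) when 4-methoxyphenyl replaced 3,4-dichlorophenyl. Going back toward a dihalophenyl group, the number for compound 4 is expected to rise, though a fluorine-for-chlorine pairing has no measured counterpart here, so the full size of that step cannot be assumed. The expected step is a number 67 percentage points higher from compound 3 to compound 4 (beyond the scatter). Compound 4 is estimated at -30%, within -85% to 15%.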

Compound 4, a percentage reported as activity, at one concentration (the size of the read-out at that concentration, not a potency): -20%
For compound 4 the middle estimate is 10 percentage points below the measured one; measured number inside the range.
By their numbers in this assay, from the lowest: compound 3; then compound 2; then compound 4; then compound 1.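

In this assay, the rise on leaving 4-methoxyphenyl at the carbonyl carbon is not confined to 3,4-dichlorophenyl, since 3,4-difluorophenyl also gives a number 77 percentage points higher from compound 3 to compound 4 (beyond the scatter) on the same core. Among the compounds shown here, the two dihalophenyl groups also differ from each other, with a number 29 percentage points lower from compound 1 to compound 4 (beyond the scatter) as the first measured halogen exchange at this carbon, and that step is the smaller of the two. Nothing available explains either step.

Going by these compounds, whether 4-aminophenyl or 4-fluorophenyl on the carbonyl carbon would keep the number near that of compound 3 remains open.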